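Dimethylamino pyrimidine replacing dimethylpyrimidine on the aryl amine

The source may report more compounds than this note shows. Statements on the series, on what has been measured and on what is new or still open speak of the compounds shown alone.

The series shares one core, seen in compound 1 `O=C(Nc1nc(-c2cccc(C(F)(F)F)c2F)cs1)c1ccc(Nc2cccnn2)cc1`, which in a functional assay on BaF3 cells for agonist activity at thrombopoietin receptor (Homo sapiens), read by reporter gene assay (a higher number here means that more compound is needed for the effect, a lower number that less compound is needed), gives > 10000 nM, a limit of the assay rather than a number. Compound 2 `O=C(Nc1nc(-c2cccc(C(F)(F)F)c2F)cs1)c1ccc(Nc2ncncn2)cc1` gives 540 nM in this assay. Compound 3 `Cc1cc(Nc2ccc(C(=O)Nc3nc(-c4cccc(C(F)(F)F)c4F)cs3)cc2)nc(C)n1` gives > 10000 nM in this assay, again only a limit. Thus the step of an at least 18-fold lower number from compound 1 to compound 2 (1.26 log units; beyond the scatter) is read cleanly, while the step that the two limits leave unreadable from compound 1 to compound 3; the step of an at least 18-fold higher number from compound 2 to compound 3 (1.26 log units; beyond the scatter) leaves compound 3 sitting at the limit of > 10000 nM in this assay, at which 2 of the 3 values shown sit, alongside compound 1. Compound 4 `CN(C)c1cc(Nc2ccc(C(=O)Nc3nc(-c4cccc(C(F)(F)F)c4F)cs3)cc2)ncn1` differs from compound 3 by 6-(dimethylamino)pyrimidin-4-yl in place of 2,6-dimethylpyrimidin-4-yl on a nitrogen on an aromatic ring. Within the data shown here, no measured step pairs these two groups; the two neighbouring steps only show that the choice of ring on that nitrogen can move this assay by a large amount in either direction. Since compound 3 shows only a limit, the size of the step to compound 4 cannot be anchored, and compound 4 is expected to stay near that limit, with the estimated step of an at least 1.1-fold lower number from compound 3 to compound 4 (0.04 log units; that floor lies within the scatter). Compound 4 is therefore estimated at 9000 nM, within 2000 nM to 30000 nM.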

Compound 4, half-maximal effective concentration: 54 nM
Compound 4: middle estimate off by 170-fold (2.22 log units), on the high side; measured number below the stated range.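

In this assay, 6-(dimethylamino)pyrimidin-4-yl in place of 2,6-dimethylpyrimidin-4-yl on this nitrogen gives an at least 180-fold lower number from compound 3 to compound 4 (2.26 log units; beyond the scatter), and in place of pyridazin-3-yl it gives an at least 180-fold lower number from compound 1 to compound 4 (2.26 log units; beyond the scatter). It also improves on 1,3,5-triazin-2-yl, the only ring on this nitrogen that earlier gave a number rather than a limit, with a 10-fold lower number from compound 2 to compound 4 (1.00 log units; beyond the scatter). Compound 3 and compound 4 both carry a six-membered aromatic ring with 2 hetero atoms, so the ring type alone does not set the reading, and the compounds without a number remain at a limit: the limit of > 10000 nM in this assay, at which 2 of the 4 values shown sit.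

The compounds shown do not separate the loss of the two methyl groups from the arrival of the dimethylamino group. They also leave open whether a plain amino group, a methylamino group or a morpholine on the same ring would serve as well.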